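A few compounds are considered here, and "the series" means these few. Any claim that something is new, unique, unknown or untested is made for them only; others in the source may bear on it.

Compound 1 `CCOC(=O)[C@H](CCC(=O)O)NC(=O)c1ccc(Sc2nc3cc(N)cc(N)c3nc2-c2ccccc2)cc1` in a functional assay on NCI-H460 cells (Homo sapiens) for inhibition, read by sulforhodamine B assay, with a stated time of 48 h (a lower number here means a stronger inhibitor of growth, a higher number a weaker inhibitor of growth), gives < 100000 nM, a limit of the assay rather than a number.
Compound 2 `Nc1cc(N)c2nc(-c3ccccc3)c(Oc3ccc(F)cc3)nc2c1` in this assay gives < 100000 nM, again a limit.
Compound 3 `CCOC(=O)[C@H](CCC(=O)O)NC(=O)c1ccc(CNc2nc3cc(N)cc(N)c3nc2-c2ccccc2)cc1` in this assay gives < 100000 nM, also a limit.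

Where compound 2 stands can therefore be said only loosely: in this assay it sits at the same limit as the other two measured compounds, and none of the three gives a number to rank them by. The one thing the measured set shows is the limit of < 100000 nM in this assay, at which 3 of the 3 values shown sit. For the measured compounds named here, no pair among compounds 1, 2 and 3 differs in a single place, so no measured step can be drawn from them.

Compound 4 `Nc1cc(N)c2nc(-c3ccccc3)c(NCc3ccc(F)cc3)nc2c1` is the unmeasured partner of compound 2. The change is (4-fluorobenzyl)amino in place of 4-fluorophenoxy on an aromatic carbon. Going by the values given here, since every measured value sits at the limit, there is no step on which to lean, and the expectation from compound 2 to compound 4 is for no change beyond the usual scatter, with a fair chance that compound 4 too will be reported only as a limit. The estimate for compound 4 in this assay is 40000 nM, with a range from 5000 nM to 100000 nM, which means an expected step that the limit leaves unreadable from compound 2 to compound 4.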

Compound 4, concentration for total growth inhibition: 25700 nM
Beside the measured number, compound 4's estimate is 1.6-fold (0.19 log units) above it; low and high end bracket the measured number.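

No step can be read from compound 2 to compound 4, because compound 2 is reported only as a limit: the limit of < 100000 nM in this assay, at which 3 of the 4 values shown sit.

The compounds shown leave open whether (4-fluorobenzyl)amino in place of 4-fluorophenoxy on this aromatic carbon makes compound 4 a stronger or a weaker inhibitor of growth than compound 2 in this assay.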